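Notes on the shared core: benzyl to propargyl step

The compounds below may be only part of what the source reports. "The series", "measured", "known", "first", "only" and "open" are said of these compounds alone.

Measured so far in an assay on PC-12 cells for displacement of a labelled ligand from vesicular acetylcholine transporter (Homo sapiens); on this read-out lower numbers stand for stronger inhibition and higher numbers for weaker inhibition:
compound 1 `OC1CN(Cc2ccccc2)CCC1N1CCN(c2ccccc2)CC1` gives 57 nM
compound 2 `OC1CN(Cc2cccc(Br)c2)CCC1N1CCN(c2ccccc2)CC1` gives 66 nM
compound 3 `OC1CCN(Cc2cccc(Br)c2)CC1N1CCN(c2ccccc2)CC1` gives 46 nM

Compound 3 shows the smallest of the three numbers, but its gaps to compound 1 and to compound 2 both sit within the usual scatter, so no ranking among the three is claimed. For the measured compounds named here, the only step measured within the set is a 1.2-fold higher number from compound 1 to compound 2 (0.06 log units; within the scatter), a change confined to a substituent on the aromatic ring; it neither raises nor lowers the number beyond the scatter.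

Compound 4 `C#CCN1CCC(O)C(N2CCN(c3ccccc3)CC2)C1` differs from compound 3 by ethynyl in place of 3-bromophenyl on a saturated chain carbon bound to an amine nitrogen in a ring. Going by the values given here, no measured step covers removal of the aromatic ring itself, so the step from compound 1 to compound 2 bears on this change only loosely; it says that a bromo substituent on that ring hardly matters, not what happens when the ring goes. With the ring gone the expectation is for a higher number in this assay, of uncertain size, estimated as a 3.3-fold higher number from compound 3 to compound 4 (0.51 log units; beyond the scatter). For compound 4 the estimate is 150 nM, with a range from 40 nM to 600 nM.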

Compound 4, half-maximal inhibitory concentration: > 100 nM
Compound 4: no number, only a limit (the forecaster's own chance of this, stated with the estimate: 5%); the middle value does not contradict the limit.
By their numbers in this assay, from the lowest: compounds 3, 1 and 2 (each within the scatter of the next). At a limit, above all of these: compound 4.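

Compound 4 gives a limit and not a number in this assay: the limit of > 100 nM in this assay, at which 1 of the 4 values shown sits.

Even so, replacing 3-bromophenyl with ethynyl, or 3-bromobenzyl with propargyl when cut one bond further out, gives an at least 2.1-fold higher number from compound 3 to compound 4 (0.33 log units; beyond the scatter), and this size is bounded on one side only. The earlier step changed only a substituent on the aromatic ring and stayed within the scatter, whereas this change removes the ring and goes beyond it, so this position tolerates a bromo substituent on the ring but not this loss of the whole 3-bromobenzyl group.

From the compounds shown here alone, how large the step really is stays open. The compounds shown also do not separate loss of the aromatic ring from loss of chain size, and a propyl chain or a phenethyl group in this place would bear on that.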